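The source may report more compounds than this note shows. Statements on the series, on what has been measured and on what is new or still open speak of the compounds shown alone.

Measured so far:
compound 1 `CCOc1ccccc1Cc1cnc(N)nc1N` — 24500 nM
compound 2 `NC(=O)COc1ccccc1Cc1cnc(N)nc1N` — 33900 nM

In an assay for inhibition of Dihydrofolate reductase (Gallus gallus) (a higher number here means a weaker inhibitor, a lower number a stronger inhibitor), compound 1 gives 24500 nM, the lowest of the two numbers; its nearest neighbour is compound 2, separated by a 1.4-fold higher number from compound 1 to compound 2 (0.14 log units; within the scatter). Compound 3 `CCCCCCOc1ccccc1Cc1cnc(N)nc1N` differs from compound 1 by butyl in place of hydrogen on a saturated chain carbon, two bonds along the chain from an oxygen on an aromatic ring. Within the data shown here, only the step from compound 1 to compound 2 touches the same chain, and it stayed within the scatter, so no measured step speaks directly to lengthening that chain. A modest move to a lower number in this assay is expected, a 2.0-fold lower number from compound 1 to compound 3 (0.31 log units; beyond the scatter), with wide uncertainty. Compound 3 is estimated at 12000 nM, range 3000 nM to 50000 nM.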

Compound 3, inhibition constant: 7940 nM
The estimate for compound 3 lay 1.5-fold (0.18 log units) above the measured number, within the range that was stated.
By their numbers in this assay, from the lowest: compound 3; then compounds 1 and 2 (each within the scatter of the next).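

In this assay, among these compounds, lengthening ethoxy to hexyloxy gives the first step on this chain that lies beyond the scatter (a 3.1-fold lower number from compound 1 to compound 3 (0.49 log units; beyond the scatter)). Pentyl in place of carbamoyl also lies beyond it (a 4.3-fold lower number from compound 2 to compound 3 (0.63 log units; beyond the scatter)), so compound 3 stands lowest of the three, while compounds 1 and 2 remain within the scatter of each other. Nothing at hand accounts for either step. With only these chains, no dependence on chain length can be drawn. As far as these compounds go, whether a longer chain such as octyl, or an amine or a carboxylic acid carried on the chain, keeps the number this low stays open.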